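Moving the fluorine on a saturated-carbon aryl group

The source may hold more compounds than are shown below. What is called first, only, known or untested is meant among the compounds shown, and "the series" means these compounds.

Measured compounds:
compound 1 `COc1ccc(C2CC(c3ccc(Br)cc3)=NN2C(=O)C2COc3ccccc3O2)cc1` 9010 nM
compound 2 `COc1ccc(C2=NN(C(=O)C3COc4ccccc4O3)C(c3ccc(F)cc3)C2)cc1` 6190 nM
compound 3 `O=C(C1COc2ccccc2O1)N1N=C(c2ccc(Br)cc2)CC1c1cccc(F)c1` 7810 nM

All three were tested in a functional assay on WM 266-4 cells (Homo sapiens) for inhibition, read by MTT assay, with a stated time of 24 h; a lower number here means a stronger inhibitor of growth, a higher number a weaker inhibitor of growth. Compound 3 gives 7810 nM, a number close to those of compound 1 and compound 2, the gaps lying within the usual scatter. Compound 4 `O=C(C1COc2ccccc2O1)N1N=C(c2ccc(Br)cc2)CC1c1ccc(F)cc1` differs from compound 3 only in the shift (4-fluorophenyl in place of 3-fluorophenyl on a saturated ring carbon). Within the data shown here, the one comparable step, a 1.2-fold lower number from compound 1 to compound 3 (0.06 log units; within the scatter), changed the group on that same saturated ring carbon and produced no shift beyond the scatter. Compound 2, which also carries a 4-fluorophenyl group, gives 6190 nM. Compound 4 is therefore expected to change the number by a 1.1-fold lower number from compound 3 to compound 4 (0.05 log units; within the scatter), nothing beyond the scatter. Compound 4 is estimated at 7000 nM, in a range from 3500 nM to 14000 nM.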

Compound 4, concentration for 50% growth inhibition: 5630 nM
For compound 4 the middle estimate is 1.2-fold (0.09 log units) above the measured one; low and high end bracket the measured number.
By their numbers in this assay, from the lowest: compounds 4, 2, 3 and 1 (each within the scatter of the next).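

In this assay, moving the fluorine to give 4-fluorophenyl in place of 3-fluorophenyl on the saturated ring carbon produces a 1.4-fold lower number from compound 3 to compound 4 (0.14 log units; within the scatter), so this shift does not separate the two compounds. Two further single changes behave alike: bromo in place of methoxy gives a 1.1-fold lower number from compound 2 to compound 4 (0.04 log units; within the scatter), and fluoro in place of methoxy gives a 1.6-fold lower number from compound 1 to compound 4 (0.20 log units; within the scatter). Nothing available explains these small steps. Still open, going by these compounds, is whether a different group on that aryl ring, such as an amine or a carboxylic acid in place of the fluorine, would move the number beyond the scatter.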